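Swapping a Five-Membered Ring for Pyridine at the Amide

A few compounds are considered here, and "the series" means these few. Any claim that something is new, unique, unknown or untested is made for them only; others in the source may bear on it.

Measured compounds:
Compound 1 `Cc1ccccc1N/C(=N\C#N)N1CCN(C(=O)Cc2ccoc2)C(c2ccccc2)C1` gives 220 nM in a functional assay for antagonist activity at P2X purinoceptor 7 (Homo sapiens), read by FLIPR and calcium flux; a lower number here means a stronger inhibitor, a higher number a weaker inhibitor.
Compound 2 `Cc1ccccc1N/C(=N\C#N)N1CCN(C(=O)Cc2ccsc2)C(c2ccccc2)C1` gives 71 nM in this assay.

Compound 2 holds the lowest of the two numbers, and compound 1 sits next to it with a higher number. Going by the values given here, the single step between them, a 3.1-fold lower number from compound 1 to compound 2 (0.49 log units; beyond the scatter), is the only change measured so far, and it concerns the same position as the one now in question.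

Compound 3 `Cc1ccccc1N/C(=N\C#N)N1CCN(C(=O)Cc2cccnc2)C(c2ccccc2)C1` is the unmeasured compound. It differs from compound 2 as follows: pyridin-3-yl in place of thiophen-3-yl on a saturated chain carbon bound to a carbonyl carbon. Among the compounds with values here, the one measured step shows that exchanging the ring on this saturated chain carbon can move this assay beyond the scatter, so a shift of similar size is plausible here. Nothing measured shows what pyridin-3-yl does at this place, so the direction rests on judgement alone; a weaker inhibitor is expected, with a step of a 2.8-fold higher number from compound 2 to compound 3 (0.45 log units; beyond the scatter) from compound 2. Compound 3 is therefore estimated at 200 nM in this assay, with a range from 60 nM to 700 nM.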

Compound 3, half-maximal inhibitory concentration: 40 nM
The estimate for compound 3 lay 5.0-fold (0.70 log units) above the measured number; measured number outside the range, below it.
By their numbers in this assay, from the lowest: compounds 3 and 2 (each within the scatter of the next); then compound 1.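

The change from a five-membered to a six-membered aromatic ring does not separate these two compounds in this assay: the record shows a 1.8-fold lower number from compound 2 to compound 3 (0.25 log units; within the scatter), so pyridin-3-yl and thiophen-3-yl cannot be ranked at this place on a saturated chain carbon bound to a carbonyl carbon. The larger ring, with its 6 heavy atoms in place of 5, is therefore compatible with inhibition at the level seen for thiophen-3-yl, and ring size alone does not set the result in this small set. The furan-3-yl compound now stands apart from both others, with a 5.5-fold lower number from compound 1 to compound 3 (0.74 log units; beyond the scatter) in the same assay, but no supporting information here explains that gap.

Going by these compounds, what stays open is whether the ring nitrogen matters at all, since a plain phenyl ring and the pyridin-2-yl and pyridin-4-yl groups would test that directly at this place. On these data alone, it is also open whether an aromatic ring is needed here, which a saturated ring such as cyclohexyl or a longer chain carrying the pyridin-3-yl group could begin to answer.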